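Moving a methyl group on a phenyl substituent

A few compounds are considered here, and "the series" means these few. Any claim that something is new, unique, unknown or untested is made for them only; others in the source may bear on it.

Values in a functional assay on HeLa cells (Homo sapiens) for antiproliferative activity, with a stated time of 5 days (a higher number here means a weaker inhibitor, a lower number a stronger inhibitor), follow
Compound 1 `Cc1ccc(-n2nc(-c3ccc4ccccc4c3)nc2N2C(=O)COC23C=CC(=O)C=C3)cc1` gives 150 nM
Compound 2 `Cc1ccccc1-n1nc(-c2cccc3ccccc23)nc1N1C(=O)COC12C=CC(=O)C=C2` gives 100 nM

Within the data shown here, only two numbers are known so far. Compound 2 (100 nM) lies within the usual scatter of compound 1 (150 nM), so the two cannot be ranked.

The next molecule, compound 3 `Cc1ccc(-n2nc(-c3cccc4ccccc34)nc2N2C(=O)COC23C=CC(=O)C=C3)cc1`, has exactly the same atoms as compound 2, joined differently. It carries 4-methylphenyl in place of 2-methylphenyl on an aromatic nitrogen. The rest of the molecule, including the naphthalen-1-yl group, stays the same.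

Among the measured compounds shown here, no two measured compounds differ in only one place, so this change has no direct precedent. The only hint is indirect: compound 1 also carries 4-methylphenyl and gives (150 nM) in this assay, though it differs from compound 2 in more than one place. On that thin basis, no change beyond the scatter is expected. The expected step of a 1.3-fold higher number from compound 2 to compound 3 (0.11 log units; within the scatter) is correspondingly small. For compound 3 the estimated value is (130 nM), with an expected range from 50 nM to 340 nM in this measurement.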

Compound 3, half-maximal inhibitory concentration: 140 nM
The estimate for compound 3 lay 1.1-fold (0.03 log units) below the measured number; low and high end bracket the measured number.
By their numbers in this assay, from the lowest: compounds 2, 3 and 1 (each within the scatter of the next).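

In this assay, replacing 2-methylphenyl with 4-methylphenyl on the aromatic nitrogen gives a 1.4-fold higher number from compound 2 to compound 3 (0.15 log units; within the scatter), so with a naphthalen-1-yl group in the molecule, this assay does not tell the two methylphenyl groups apart. Placing naphthalen-1-yl in the position of naphthalen-2-yl on the aromatic carbon gives a 1.1-fold lower number from compound 1 to compound 3 (0.03 log units; within the scatter), so these two groups cannot be told apart either, at least when 4-methylphenyl sits on the nitrogen. Among these compounds, these are the first direct one-place comparisons here, but no independent measurement is available to explain either result.

The compounds shown leave open whether a different group on this phenyl ring, such as a methoxy group, an amine or a carboxylic acid, would shift the number beyond the scatter. As far as these compounds go, it also remains open how 2-methylphenyl would behave alongside naphthalen-2-yl, since both methylphenyl comparisons so far rest on a single pair of compounds each.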